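This account rests on a few compounds, and the source may have more. Where it says the series, first, only, none or still open, it means among the compounds named here.

Measured compounds:
- compound 2, `CC1CC/C(=N\Nc2ccccc2Cl)c2ncc(C(=O)O)c(=O)n21`: > 1000 umol/kg
- compound 1, `CC1C/C(=N\Nc2ccccc2)c2ncc(C(=O)O)c(=O)n2C1`: > 320 umol/kg

In a functional assay on the whole organism for inhibition, with Rattus norvegicus as the target (a lower number here means that less compound is needed, a higher number that more compound is needed for the effect), compound 2 reaches only > 1000 umol/kg, which is a limit of the assay and not a number. Compound 1 likewise gives only > 320 umol/kg in this assay, again a limit. Compound 2 thus stands at the limit of > 1000 umol/kg in this assay, at which 1 of the 2 values shown sits, and the other value available sits at the limit of > 320 umol/kg in this assay, at which 1 of the 2 values shown sits. With both values being limits, no measured step can be read from the pair, and nothing is known of how large a change any alteration of the aryl group brings.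

Compound 3, `CC1CC/C(=N\Nc2cccc(Br)c2)c2ncc(C(=O)O)c(=O)n21`, differs from compound 2 by 3-bromophenyl in place of 2-chlorophenyl on an amine nitrogen. Among the compounds with values here, no measured step exists for this change, and no expectation beyond the scatter in this assay is taken in either direction; compound 3 is expected to remain near the limit. The step from compound 2 to compound 3 is estimated as a number no higher from compound 2 to compound 3 (the limit leaves the size open). For compound 3 the expected value is 1000 umol/kg, within 300 umol/kg to 3000 umol/kg, most likely reported as a limit only.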

Compound 3, dose for 50% inhibition: > 320 umol/kg
Compound 3 was reported as a limit (the forecaster's own chance of this, stated with the estimate: 80%); the middle value lies beyond the limit too.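

Compound 2 and compound 3 are both reported only as limits in this assay, so no step can be read between them. The compounds shown leave open whether any group on the amine nitrogen gives an actual numeric value in this assay.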